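The compounds below may be only part of what the source reports. "The series", "measured", "known", "first", "only" and "open" are said of these compounds alone.

In a functional assay on CHO cells for antagonist activity at sphingosine 1-phosphate receptor 2 (Homo sapiens), read by fluorescence and calcium flux, with a stated time of 3 min (a higher number here means a weaker inhibitor, a lower number a stronger inhibitor), three close relatives of one shared core have been measured. Compound 1 `CCOc1cc(NC(=O)NCc2cc(C)c(-c3cn(C)nc3C(F)(F)F)nn2)cc(C#N)n1` gives 11000 nM. Compound 2 `CCOc1cc(NC(=O)NCc2cc(C)c(-c3cn(C)nc3C(F)(F)F)nn2)cc(C)n1` gives 54000 nM, and compound 3 `CCOc1nc(C)cc(NC(=O)NCc2cc(C)c(-c3cn(C)nc3C(F)(F)F)nn2)c1Cl` gives 8700 nM. Compound 3 has the lowest number of the three, but its gap to compound 1 is within the scatter, so those two cannot be ranked against each other; only compound 2 stands clearly apart. Compound 4 `CCOc1nc(C)cc(NC(=O)NCc2cc(C)c(-c3cn(C)nc3C(F)(F)F)nn2)c1C#N` differs from compound 3 by cyano in place of chloro on an aromatic carbon. Among the measured compounds shown here, two measured steps bear on this change. Replacing cyano by methyl gave a 4.9-fold higher number from compound 1 to compound 2 (0.69 log units; beyond the scatter), so a cyano group on this ring has gone with a lower number than methyl. Adding chloro to the ring gave a 6.2-fold lower number from compound 2 to compound 3 (0.79 log units; beyond the scatter), so chloro likewise went with a lower number than hydrogen. Swapping one of these two favourable groups for the other is therefore expected to change little, and the estimated step of a 1.1-fold lower number from compound 3 to compound 4 (0.04 log units; within the scatter) is expected to stay within the scatter. Compound 4 is expected to give about 8000 nM, with a likely range from 3000 nM to 25000 nM.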

Compound 4, half-maximal inhibitory concentration: > 20000000 nM
Compound 4: no number, only a limit; the forecaster's own chance of this, stated with the estimate: 5%; at least 2500-fold (3.39 log units) between middle value and limit.
By their numbers in this assay, from the lowest: compounds 3 and 1 (each within the scatter of the next); then compound 2. At a limit, above all of these: compound 4.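

At this ring carbon, ortho to an ethoxy group and para to a methyl group, chloro and cyano are not interchangeable: an at least 2200-fold higher number from compound 3 to compound 4 (3.36 log units; beyond the scatter). Starting from hydrogen, the two groups move the number in opposite directions, with chloro giving a 6.2-fold lower number from compound 2 to compound 3 (0.79 log units; beyond the scatter) and cyano giving an at least 370-fold higher number from compound 2 to compound 4 (2.56 log units; beyond the scatter), so the step from compound 1 to compound 2 does not carry over to this carbon. Compound 4 has no measured number in this assay, only a limit of the assay: the limit of > 20000000 nM in this assay, at which 1 of the 4 values shown sits.

The compounds shown leave open whether cyano alone gives this result on this carbon or whether chloro is the exception among small groups. A fluoro, a bromo, a methoxy or an amine here would separate those two readings, and nothing shown explains the result for cyano.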